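Methoxy in place of hydrogen on compound 3

A few compounds are considered here, and "the series" means these few. Any claim that something is new, unique, unknown or untested is made for them only; others in the source may bear on it.

Values in a functional assay on K562 cells (Homo sapiens) for cytotoxicity, read by trypan blue exclusion, with a stated time of 96 h (on this read-out lower numbers stand for stronger inhibition and higher numbers for weaker inhibition), for the measured compounds:
compound 1 `COc1ccc(CS(=O)(=O)/C=C/c2ccccc2OC)cc1N` gives 7500 nM as its number
compound 2 `COc1ccc(/C=C/S(=O)(=O)Cc2ccc(OC)c([N+](=O)[O-])c2)cc1` gives 25000 nM as its number
compound 3 `COc1ccc(/C=C/S(=O)(=O)Cc2ccc(OC)c(N)c2)cc1` gives 2500 nM as its number

Compound 3 holds the lowest of the three numbers. Compound 4 `COc1ccc(/C=C/S(=O)(=O)Cc2ccc(OC)c(N)c2)c(OC)c1` differs from it by methoxy in place of hydrogen on an aromatic carbon with methoxy in place of hydrogen on an aromatic carbon, ortho to a large group. Going by the values given here, the only measured step, a 10-fold lower number from compound 2 to compound 3 (1.00 log units; beyond the scatter) for amino in place of nitro, involves a different change and indicates only the scale of movement. Compound 1 also has a methoxy ortho to a large group, yet gives 7500 nM as its number, so it offers no support for a large drop. In this assay the expected change is a 2.5-fold lower number from compound 3 to compound 4 (0.40 log units; beyond the scatter) with weak support for its direction. For compound 4 the estimated value is 1000 nM with a range from 120 nM to 6000 nM on this estimate.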

Compound 4, half-maximal inhibitory concentration: 500 nM
Compound 4: the middle estimate sits 2.0-fold (0.30 log units) above what was measured; the measured number falls inside the stated range.
By their numbers in this assay, from the lowest: compound 4; then compound 3; then compound 1; then compound 2.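

In this assay, methoxy in place of hydrogen on the aromatic carbon ortho to a large group and meta to a methoxy group gives a 5.0-fold lower number from compound 3 to compound 4 (0.70 log units; beyond the scatter), so this position can take the added group with a gain. Methoxy in place of hydrogen on an aromatic carbon also gives a 15-fold lower number from compound 1 to compound 4 (1.18 log units; beyond the scatter), so the lower number does not rest on a single starting compound. Nothing available explains the drop.

From the compounds shown here alone, whether the gain belongs to methoxy itself stays open. Ethoxy, hydroxyl or chlorine on the same carbon would test that.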